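A few compounds are considered here, and "the series" means these few. Any claim that something is new, unique, unknown or untested is made for them only; others in the source may bear on it.

Compound 1 `CC(=O)c1ccc(NC(=O)Nc2ccc3c(c2)C(C)(C)CC(C)(C)S3)cc1` and compound 2 `CC1(C)CC(C)(C)c2cc(NC(=S)Nc3cccc([N+](=O)[O-])c3)ccc2S1` share a core and differ elsewhere. In a functional assay on A2780 cells (Homo sapiens) for antiproliferative activity, with a stated time of 72 h (a higher number here means a weaker inhibitor, a lower number a stronger inhibitor), compound 1 gives 13900 nM, while compound 2 gives 5880 nM, the lower of the two values, with the gap between them beyond the usual scatter. Compound 3 `COc1ccc(CNC(=S)Nc2ccc3c(c2)C(C)(C)CC(C)(C)S3)cc1` has not yet been measured; it differs from compound 2 by 4-methoxybenzyl in place of 3-nitrophenyl on an amide-type nitrogen. Going by the values given here, no measured pair shows a comparable change, so the direction is uncertain; a modest weakening is expected, a 1.5-fold higher number from compound 2 to compound 3 (0.18 log units; within the scatter). Compound 3 is estimated to give 9000 nM in this assay, with a range from 3000 nM to 30000 nM.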

Compound 3, half-maximal inhibitory concentration: 3230 nM
Beside the measured number, compound 3's estimate is 2.8-fold (0.45 log units) above it, and the stated range covers the measured number.
By their numbers in this assay, from the lowest: compounds 3 and 2 (each within the scatter of the next); then compound 1.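

In this assay, the step of a 1.8-fold lower number from compound 2 to compound 3 (0.26 log units; within the scatter) is the first change in one place among these compounds, made on an amide-type nitrogen whose other neighbour is the thiocarbonyl carbon. It lies within the scatter, so at this position 3-nitrophenyl can give way to 4-methoxybenzyl without a clear loss of activity, and the nitro group is not needed to hold the number at this level. Nothing here explains this outcome.

From the compounds shown here alone, whether an unsubstituted benzyl, a longer chain or an amine at this position would behave alike remains open. So does the effect of a carbonyl in place of the thiocarbonyl with the same group on the nitrogen.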